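Shrinking the Amine Ring at the End of the Chain

The source may hold more compounds than are shown below. What is called first, only, known or untested is meant among the compounds shown, and "the series" means these compounds.

Three compounds share one core and differ only in the side chain that carries a basic amine. Compound 1 `O=c1cc(-c2ccccc2)oc2cc(O)c(OCCCN3CCCCC3)c(O)c12` was tested in a functional assay on A549 cells (Homo sapiens) for antiproliferative activity, read by MTT assay, with a stated time of 48 h (a higher number here means a weaker inhibitor, a lower number a stronger inhibitor), and for compound 1 the outcome is only a limit, > 100000 nM, not a number. Compound 2 `O=c1cc(-c2ccccc2)oc2cc(O)c(OCCCCN3CCCCC3)c(O)c12` gives 75000 nM in this assay, and compound 3 `COc1cc2oc(-c3ccccc3)cc(=O)c2c(O)c1OCCCCN1CCCCC1` gives 34000 nM. Of the two actual numbers, compound 2 holds the highest; its nearest neighbour is compound 3, reached by a 2.2-fold lower number from compound 2 to compound 3 (0.34 log units; beyond the scatter). The other measured step, an at least 1.3-fold lower number from compound 1 to compound 2 (0.12 log units; that floor lies within the scatter), has only a floor because compound 1 sits at the limit (the limit of > 100000 nM in this assay, at which 1 of the 3 values shown sits).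

Compound 4 `O=c1cc(-c2ccccc2)oc2cc(O)c(OCCCCN3CCCC3)c(O)c12` keeps the chain of compound 2 and alters only the ring at its end: pyrrolidin-1-yl in place of piperidin-1-yl on a saturated chain carbon, four bonds along the chain from an oxygen on an aromatic ring. Neither measured step concerns this ring, so they give only a loose guide: altering the chain or methylating an oxygen moved the number modestly at most. Swapping one saturated amine ring for another of this kind is expected to give no step beyond the scatter, so no change at the digits printed from compound 2 to compound 4 (within the scatter) is the step expected. Compound 4 is therefore estimated at 75000 nM, within a range from 30000 nM to 150000 nM.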

Compound 4, half-maximal inhibitory concentration: 51000 nM
The estimate for compound 4 lay 1.5-fold (0.17 log units) above the measured number, within the range that was stated.
By their numbers in this assay, from the lowest: compounds 3, 4 and 2 (each within the scatter of the next, the first and the last beyond it). At a limit, above all of these: compound 1.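

Here the ring at the end of the chain changes for the first time, and in this assay the result is a 1.5-fold lower number from compound 2 to compound 4 (0.17 log units; within the scatter), so on a saturated chain carbon, four bonds along the chain from an oxygen on an aromatic ring, this assay does not tell pyrrolidin-1-yl from piperidin-1-yl. The second new step, an at least 1.9-fold lower number from compound 1 to compound 4 (0.29 log units; that floor lies within the scatter), alters the chain and the ring together and gives only a floor, so it cannot be assigned to either change and says nothing further about the ring alone. Compound 1 is given only as a limit, not as a number: the limit of > 100000 nM in this assay, at which 1 of the 4 values shown sits.

Still open, on these data alone, is whether an end group of a different kind, such as a morpholine ring with its added oxygen or an open-chain dimethylamino group, would separate from these two saturated rings on the same chain. Also open, as far as these compounds go, is whether pyrrolidin-1-yl would behave the same way on the core of compound 3, which carries a methyl on an oxygen on an aromatic ring, or at the end of a longer chain.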